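Swapping fluoro for methylamino on an aryl ring

A few compounds are considered here, and "the series" means these few. Any claim that something is new, unique, unknown or untested is made for them only; others in the source may bear on it.

Measured compounds:
compound 1, `CC(C)n1nc2c(c1-c1ccc(Cl)cc1)CCNCC2`, 20 nM
compound 2, `CC(C)n1nc2c(c1-c1ccc(F)cc1)CCNCC2`, 170 nM

Both compounds were tested in an ADME assay on membranes from Cortex for displacement of a labelled ligand from Adrenergic receptor alpha-1 (Rattus norvegicus), read by radioligand binding, with a stated time of 60 min; a higher number here means a weaker inhibitor, a lower number a stronger inhibitor. Among the compounds with values here, compound 2 has the higher of the two numbers, which means it is the weaker of the two; its only neighbour is compound 1, and the step of an 8.5-fold higher number from compound 1 to compound 2 (0.93 log units; beyond the scatter) is clear of the scatter. Compound 3, `CNc1ccc(-c2c3c(nn2C(C)C)CCNCC3)cc1`, has not been measured. It differs from compound 2 by one change: methylamino in place of fluoro on an aromatic carbon.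

Within the data shown here, no measured step exchanges a halogen for an amino-type group, so the only guide is the halogen step itself. That step, an 8.5-fold higher number from compound 1 to compound 2 (0.93 log units; beyond the scatter), shows that a single change at this aromatic carbon can move the number modestly, in either sense. Among the measured compounds shown here, with no direct precedent, the expected step of a 1.4-fold lower number from compound 2 to compound 3 (0.15 log units; within the scatter) is kept small, and the uncertainty wide to cover both a gain and a loss. Compound 3 is therefore estimated at 120 nM, with a likely range from 25 nM to 600 nM.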

Compound 3, inhibition constant: 16 nM
Estimate against measurement, compound 3: 7.5-fold (0.88 log units) above; measured number outside the range, below it.
By their numbers in this assay, from the lowest: compounds 3 and 1 (each within the scatter of the next); then compound 2.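

In this assay, the step of an 11-fold lower number from compound 2 to compound 3 (1.03 log units; beyond the scatter) shows that the position para to a large group can take methylamino and lose nothing against the best number seen so far, so the aromatic carbon tolerates more than a halogen. The step of a 1.3-fold lower number from compound 1 to compound 3 (0.10 log units; within the scatter) puts methylamino and chloro level, which means two quite different groups give the same result here, while compound 2, with fluoro, is the weakest of the three, its steps to both others being beyond the scatter. Nothing available explains why fluoro stands apart from the other two groups, and no outside measurement bears on this result.

Within the data shown here, with only three groups at this carbon, it remains open whether the pattern depends on the hydrogen of methylamino, which a dimethylamino group would lack, or on the size of the group, which a plain amino group would reduce. A methoxy group or a bromo group at the same carbon would show whether compound 2 is a lone exception or marks a wider divide among substituents.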